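The source may hold more compounds than are shown below. What is called first, only, known or untested is meant among the compounds shown, and "the series" means these compounds.

Compound 1 `CC(C)C[C@H](N)C(=O)NS(=O)(=O)c1cccc(-c2ccncc2)c1` gives 1200 nM in an assay on isolated protein for inhibition of leucine--tRNA ligase, cytoplasmic (Homo sapiens); a lower number here means a stronger inhibitor, a higher number a weaker inhibitor. Among the compounds with values here, compound 2 `CC(C)C[C@H](N)C(=O)NS(=O)(=O)c1cccc(-c2ccccc2)c1` gives 3400 nM in this assay, the higher of the two numbers, and the single measured step, a 2.8-fold higher number from compound 1 to compound 2 (0.45 log units; beyond the scatter), separates them. Compound 3 `CC(C)C[C@H](N)C(=O)NS(=O)(=O)c1cccc(-c2cccc(N)n2)c1` differs from compound 2 by 6-aminopyridin-2-yl in place of phenyl on an aromatic carbon. A nitrogen-containing ring thus returns in place of the plain phenyl, and because the step of a 2.8-fold higher number from compound 1 to compound 2 (0.45 log units; beyond the scatter) went the other way, compound 3 is expected to show a 2.3-fold lower number from compound 2 to compound 3 (0.36 log units; beyond the scatter). Compound 3 is therefore estimated at 1500 nM, within a range from 500 nM to 4500 nM.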

Compound 3, half-maximal inhibitory concentration: 850 nM
Beside the measured number, compound 3's estimate is 1.8-fold (0.25 log units) above it; the range from low to high includes it.
By their numbers in this assay, from the lowest: compounds 3 and 1 (each within the scatter of the next); then compound 2.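

At this position, on an aromatic carbon of the ring, a second nitrogen-containing ring also improves on phenyl in this assay, with a 4.0-fold lower number from compound 2 to compound 3 (0.60 log units; beyond the scatter) as the step. Set against pyridin-4-yl, the 6-aminopyridin-2-yl group gives a 1.4-fold lower number from compound 1 to compound 3 (0.15 log units; within the scatter) and so cannot be told apart from it, which means that two different nitrogen-containing rings now stand level. Nothing available explains this result. On these data alone, compound 3 changes the ring nitrogen and adds an amino group together, so their separate shares remain open. A plain pyridin-2-yl ring or an aminophenyl ring would separate them.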